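Nitro to methoxy on the furan-bearing core of compound 3

The compounds below may be only part of what the source reports. "The series", "measured", "known", "first", "only" and "open" are said of these compounds alone.

Measured so far in a functional assay on SK-MEL-2 cells (Homo sapiens) for cytotoxicity, read by sulforhodamine B assay, with a stated time of 2 days, tested at 100 uM; on this read-out higher numbers stand for more inhibition at the one concentration tested (going by the name of the read-out) and lower numbers for less inhibition:
compound 1 `O=C(Nn1c(-c2cccc([N+](=O)[O-])c2)nc2c(-c3cccc(Cl)c3)n[nH]c2c1=O)c1ccccc1` gives 78.2%
compound 2 `COc1cccc(-c2nc3c(-c4cccc(Cl)c4)n[nH]c3c(=O)n2NC(=O)c2ccccc2)c1` gives 81.9%
compound 3 `O=C(Nn1c(-c2cccc([N+](=O)[O-])c2)nc2c(-c3ccco3)n[nH]c2c1=O)c1ccccc1` gives 23%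

Compounds 1 and 2 differ by methoxy in place of nitro on an aromatic carbon. The step between them is a number 3.7 percentage points higher from compound 1 to compound 2 (within the scatter), so the two values cannot be ordered against each other. Compound 3 differs from compound 1 by furan-2-yl in place of 3-chlorophenyl on an aromatic carbon, and here the step is a number 55.2 percentage points lower from compound 1 to compound 3 (beyond the scatter), which leaves compound 3 the lowest of the three measured compounds by a clear margin on both sides.

Compound 4 `COc1cccc(-c2nc3c(-c4ccco4)n[nH]c3c(=O)n2NC(=O)c2ccccc2)c1` has not yet been measured. It differs from compound 3 by methoxy in place of nitro on an aromatic carbon. The same change occurs once more among these compounds, from compound 1 to compound 2, where it made a number 3.7 percentage points higher from compound 1 to compound 2 (within the scatter). The place of the change is worded identically in both pairs, so it is the same change; what differs between the two pairs is the core, in the way given by furan-2-yl in place of 3-chlorophenyl on an aromatic carbon.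

Compound 4 is expected to give 27% in this assay, somewhere between 10% and 45%. For the measured compounds named here, this corresponds to an expected step of a number 4 percentage points higher from compound 3 to compound 4 (within the scatter), which rests on the one earlier instance of the change being a number 3.7 percentage points higher from compound 1 to compound 2 (within the scatter), applied to the starting value of compound 3 at 23%. Whether the change behaves alike on the core of compound 3 and on the core of compound 1 is not shown by any measured pair, and the range is kept wide for that reason.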

Compound 4, a percentage reported as inhibition, at one concentration (the size of the read-out at that concentration, not a potency): 43.2%
For compound 4 the middle estimate is 16.2 percentage points below the measured one; the measured number falls inside the stated range.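

In this assay, going from 3-nitrophenyl to 3-methoxyphenyl on the furan-2-yl core gives a step that is a number 20.2 percentage points higher from compound 3 to compound 4 (beyond the scatter), so the change does not carry over at one size from the 3-chlorophenyl core, where its step lies within the scatter: the same change on two cores in this assay, a number 3.7 percentage points higher (within the scatter) from compound 1 to compound 2 and a number 20.2 percentage points higher (beyond the scatter) from compound 3 to compound 4, 16.5 percentage points apart, beyond the scatter of two such steps

Read the other way round, furan-2-yl in place of 3-chlorophenyl lowers the number with methoxy as well as with nitro, the step with methoxy being a number 38.7 percentage points lower from compound 2 to compound 4 (beyond the scatter), so the direction is shared while the size depends on the group at the other site: the same change on two cores in this assay, a number 55.2 percentage points lower (beyond the scatter) from compound 1 to compound 3 and a number 38.7 percentage points lower (beyond the scatter) from compound 2 to compound 4, 16.5 percentage points apart, beyond the scatter of two such steps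

These two comparisons come from the same four compounds, so they show one dependence between two sites on two cores; they do not show why the step differs, whether it would recur on a third core, or how potency behaves, since the read-out comes from one concentration.

The compounds shown leave open whether an amine or a carboxylic acid in place of nitro or methoxy would follow the same dependence on the two cores. Going by these compounds, the phenyl on the amide carbonyl is also constant throughout, so the effect of a longer alkyl chain there, and whether it would alter the gap between the cores, remains open.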